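A longer chain on an inactive compound

The source may hold more compounds than are shown below. What is called first, only, known or untested is meant among the compounds shown, and "the series" means these compounds.

compound 1 `CCCCCCCCCCCCCC(=O)Nc1nnc(S[C@@H]2O[C@H](COC(C)=O)[C@H](OC(C)=O)[C@H](OC(C)=O)[C@H]2OC(C)=O)s1`: "not active" (no number reported)
compound 2 `CCCCCCCCCC(=O)Nc1nnc(S[C@@H]2O[C@H](CO)[C@H](O)[C@H](O)[C@H]2O)s1`: "not active" (no number reported)
compound 3 `CCCCCCCC(=O)Nc1nnc(S[C@@H]2O[C@H](CO)[C@H](O)[C@H](O)[C@H]2O)s1`: 56000 nM

In a functional assay on SK-OV-3 cells (Homo sapiens) for cytotoxicity, read by MTT assay, with a stated time of 24 h (on this read-out higher numbers stand for weaker inhibition and lower numbers for stronger inhibition), compound 1 has no single number, and compound 2 shares that position. Only compound 3 gives a number, 56000 nM. Compound 4 `CCCCCCCCCCCCCCCC(=O)Nc1nnc(S[C@@H]2O[C@H](COC(C)=O)[C@H](OC(C)=O)[C@H](OC(C)=O)[C@H]2OC(C)=O)s1` has not yet been measured. The structural change is ethyl in place of hydrogen on a saturated chain carbon, ten or more bonds along the chain from a carbonyl carbon. In this assay no step beyond the scatter is expected, given that compound 1 stands at "not active" (no number reported). Any number that does appear is expected to be weak, near that of compound 3 at 56000 nM. For compound 4 the estimated value is 100000 nM, with an expected range of 40000 nM to 300000 nM.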

Compound 4, half-maximal inhibitory concentration: "not active" (no number reported)
Compound 4 has no reported number here, so the estimate cannot be set against anything.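

In this assay, for the compounds shown here, neither compound 1 nor compound 4 carries a number, so no step between them can be read, and no evidence bears on the result. Still open, on these data alone, is whether chain length changes the response in this assay at all.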